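Series notes: ring change at the thiocarbonyl carbon

The source may hold more compounds than are shown below. What is called first, only, known or untested is meant among the compounds shown, and "the series" means these compounds.

Measured so far:
compound 1 `CCCOP(=O)(O)OCCSC(=S)N1CCCC1`, 67000 nM
compound 2 `CCCCCCOP(=O)(O)OCCSC(=S)N1CCCC1`, 54000 nM
compound 3 `CCCCCCCCOP(=O)(O)OCCSC(=S)N1CCCCC1`, 11900 nM

All three values come from a functional assay on MDA-MB-231 cells (Homo sapiens) for inhibition, read by MTT assay, with stated times of 18 h and 4 h; a lower number here means a stronger inhibitor, a higher number a weaker inhibitor. Compound 3 gives the lowest number of the three, and its gaps to compound 2 and to compound 1 both lie beyond the scatter. For the measured compounds named here, the only single-point step measured, a 1.2-fold lower number from compound 1 to compound 2 (0.09 log units; within the scatter), concerns the chain and lies within the scatter. Compound 4 `CCCCCCCCOP(=O)(O)OCCSC(=S)N1CCCC1` differs from compound 3 by pyrrolidin-1-yl in place of piperidin-1-yl on a thiocarbonyl carbon. Going by the values given here, no measured step bears directly on this ring change; compound 2 and compound 3 differ in both chain and ring, so their values cannot be split between the two. Because a 1.2-fold lower number from compound 1 to compound 2 (0.09 log units; within the scatter) was small, part of the gap between compound 2 and compound 3 may sit in the ring. A somewhat higher number is therefore expected for compound 4, a 2.1-fold higher number from compound 3 to compound 4 (0.32 log units; beyond the scatter). The estimate for compound 4 is 25000 nM, range 9000 nM to 60000 nM.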

Compound 4, half-maximal inhibitory concentration: 69000 nM
Compound 4: middle estimate off by 2.8-fold (0.44 log units), on the low side; the measured number lies above the stated range.
By their numbers in this assay, from the lowest: compound 3; then compounds 2, 1 and 4 (each within the scatter of the next).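

For the compounds shown here, in (this assay), the first direct reading of this position shows pyrrolidin-1-yl in place of piperidin-1-yl on the thiocarbonyl carbon giving (a 5.8-fold higher number from compound 3 to compound 4 (0.76 log units; beyond the scatter)). With pyrrolidin-1-yl held fixed, the chain changes stay within the scatter (a 1.3-fold higher number from compound 2 to compound 4 (0.11 log units; within the scatter); a 1.0-fold higher number from compound 1 to compound 4 (0.01 log units; within the scatter)), so the lower number of compound 3 tracks with piperidin-1-yl among these compounds. No evidence is available on the origin of this ring step.

As far as these compounds go, whether piperidin-1-yl gives the same step on the shorter chains of compound 1 and compound 2 remains open. So does the outcome with morpholin-4-yl or azepan-1-yl at this position.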